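The compounds below may be only part of what the source reports. "The series", "measured", "known", "first", "only" and "open" are said of these compounds alone.

Working notes on the series in a functional assay on HepG2 cells (Homo sapiens) for antiproliferative activity, read by MTT assay, with a stated time of 48 h; a higher number here means a weaker inhibitor, a lower number a stronger inhibitor. Compound 1 `Cc1cccc(-n2nncc2CN2C(=O)C3(C(C#N)=C(N)Oc4c3c3nc5ccccc5nc3c3ccccc43)c3ccccc32)c1` gives in this assay only a limit of the assay, > 50000 nM. Compound 2 `COc1ccc(-n2nncc2CN2C(=O)C3(C(C#N)=C(N)Oc4c3c3nc5ccccc5nc3c3ccccc43)c3ccccc32)cc1` likewise gives in this assay only a limit, > 50000 nM. Among the measured compounds shown here, the single step measured between two compounds, a step that the two limits leave unreadable from compound 1 to compound 2, is therefore unreadable in size and direction. Compound 3 `COc1ccc(-n2nncc2CN2C(=O)C3(C(C#N)=C(N)Oc4c(N)cc5nc6ccccc6nc5c43)c3ccccc32)cc1` also gives in this assay only a limit, > 50000 nM. Compound 3 thus stands where the other two stand, with no number of its own, and nothing among the three values orders it against them. What the measured set shares is the limit of > 50000 nM in this assay, at which 3 of the 3 values shown sit.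

Compound 4 `COc1cc(-n2nncc2CN2C(=O)C3(C(C#N)=C(N)Oc4c(N)cc5nc6ccccc6nc5c43)c3ccccc32)c(OC)cc1Cl` is not yet measured. It differs from compound 3 in one place: 4-chloro-2,5-dimethoxyphenyl in place of 4-methoxyphenyl on an aromatic nitrogen. For the measured compounds named here, the only measured step in hand, a step that the two limits leave unreadable from compound 1 to compound 2, also exchanges the group on that aromatic nitrogen, but it is unreadable, so no size or direction can be drawn from it for the present change. Because every measured value sits at the limit of > 50000 nM in this assay, at which 3 of the 3 values shown sit, compound 4 is expected to remain weak as well. The expected step that the limit leaves unreadable from compound 3 to compound 4 is estimated as none beyond the scatter. The estimate for compound 4 in this assay is 70000 nM, with a range from 20000 nM to 300000 nM, most likely again reported only as a limit.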

Compound 4, half-maximal inhibitory concentration: > 50000 nM
Compound 4: a limit, no number (the forecaster's own chance of this, stated with the estimate: 80%); the middle value lies beyond the limit too.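

In this assay compound 4 gives > 50000 nM, a limit of the assay and not a number. Compound 3 also stands at a limit, so the step between compound 3 and compound 4 cannot be read in size or direction. The compounds shown leave open whether any change on the aromatic nitrogen or the shared core gives a readable value, as all share one result: the limit of > 50000 nM in this assay, at which 4 of the 4 values shown sit.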